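Smaller ring group in place of a fused one: compound 4

The source may hold more compounds than are shown below. What is called first, only, known or untested is meant among the compounds shown, and "the series" means these compounds.

Measured so far:
compound 1 `CNC(=O)c1cc(-c2cnc(NCc3c(F)ccc4c3CCO4)c3cn[nH]c(=O)c23)n(C)n1` — 2.1
compound 2 `O=C1CCCN1c1cnc(NCc2c(F)ccc3c2CCO3)c2cn[nH]c(=O)c12` — 1.8
compound 3 `O=C1c2ccccc2CN1c1cnc(NCc2c(F)ccc3c2CCO3)n2cnnc12` — 2.7
compound 4 `C[C@@H]1CC(=O)N(c2cnc(NCc3c(F)ccc4c3CCO4)n3cnnc23)C1` — not yet measured

In a physicochemical assay for lipophilicity, using the shake flask method, in phosphate buffer, measured as octanol-water partition, with a stated time of 30 min, at pH 7.4 (on this read-out higher numbers stand for higher lipophilicity and lower numbers for lower lipophilicity), compound 3 gives 2.7, the highest of the three numbers; compound 1 gives 2.1 and compound 2 gives 1.8, both lower by more than the scatter. Compound 4 differs from compound 3 by a group of 7 heavy atoms (5 carbon, 1 nitrogen, 1 oxygen; one five-membered non-aromatic ring with 1 hetero atom) in place of a group of 10 heavy atoms (8 carbon, 1 nitrogen, 1 oxygen; one five-membered non-aromatic ring with 1 hetero atom, one six-membered aromatic ring of carbon only), on an aromatic carbon. Within the data shown here, the one measured step in which a 2-oxopyrrolidin-1-yl group enters, a number 0.30 log units lower from compound 1 to compound 2 (within the scatter), stayed within the scatter, but there the leaving group had no second ring. Here the leaving group carries a six-membered aromatic ring of carbon only and the entering group does not, so a fall beyond the scatter is expected, a number 0.60 log units lower from compound 3 to compound 4 (beyond the scatter). Compound 4 is estimated at 2.1, with a range of 1.6 to 2.6.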

Compound 4, distribution coefficient: 1.8
Compound 4: the middle estimate sits 0.30 log units above what was measured; the measured number falls inside the stated range.
By their numbers in this assay, from the lowest: compounds 2, 4 and 1 (each within the scatter of the next); then compound 3.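

On this aromatic carbon of the core shared by compound 3 and compound 4, 4-methyl-2-oxopyrrolidin-1-yl in place of the group bearing the six-membered aromatic ring of carbon only gives a number 0.90 log units lower from compound 3 to compound 4 (beyond the scatter) in this assay on this read-out. Among these compounds, on a different core, the step of a number 0.30 log units lower from compound 1 to compound 2 (within the scatter) introduced 2-oxopyrrolidin-1-yl without leaving the scatter, so this is the first step beyond the scatter for such a replacement. Nothing available accounts for the size of this step.

As far as these compounds go, the effect of the methyl group and of its defined stereocentre on this core remains open. So does the read-out with a simple amine or a carboxylic acid at this aromatic carbon.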